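Methoxycarbonyl for fluoro on the anilide of compound 3

A few compounds are considered here, and "the series" means these few. Any claim that something is new, unique, unknown or untested is made for them only; others in the source may bear on it.

The series rests on a shared core, seen in compound 1 `COc1cc2oc(-c3cccc(NC(=O)c4ccc(Cl)cc4)c3)cc(=O)c2c(OC)c1OC`, compound 2 `COC(=O)c1ccc(C(=O)Nc2cccc(-c3cc(=O)c4c(OC)c(OC)c(OC)cc4o3)c2)cc1` and compound 3 `COc1cc2oc(-c3ccc(NC(=O)c4ccc(F)cc4)cc3)cc(=O)c2c(OC)c1OC`, with the anilide ring varied. All three have been tested in a functional assay on UO-31 cells (Homo sapiens) for inhibition, read by sulforhodamine B assay, tested at 10 uM; a higher number here means more inhibition at the concentration tested (going by the name of the read-out), a lower number less inhibition. In this assay compound 1 gives 51.1%. For compound 2 this assay records only "active" (no number reported), without a number. Compound 3 stands in the same position: in this assay it is recorded as "active" (no number reported), again with no number behind it, so its place among the others cannot be fixed more closely than that.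

Compound 4 `COC(=O)c1ccc(C(=O)Nc2ccc(-c3cc(=O)c4c(OC)c(OC)c(OC)cc4o3)cc2)cc1` follows from compound 3 by one change: methoxycarbonyl in place of fluoro on an aromatic carbon. Compound 2 also carries the methoxycarbonyl group on its anilide and is recorded as active, so nothing among the numbers argues for a loss of inhibition when this group enters. Among the measured compounds shown here, since no single value for compound 3 exists, no step in this assay can be computed; the expectation is for no change beyond the scatter, with compound 4 landing near the one figure the series offers, that of compound 1. Compound 4 is therefore estimated at 50%, within a range from 25% to 75%.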

Compound 4, a percentage reported as inhibition, at one concentration (the size of the read-out at that concentration, not a potency): "active" (no number reported)
Compound 4: no number reported; no gap can be computed for the estimate.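

In this assay, among the compounds shown here, compound 3 and compound 4 are both recorded only as active, without a number, so no step between them can be read. Nothing measured here offers an explanation for this result. As far as these compounds go, it remains open how far methoxycarbonyl in place of fluoro shifts inhibition in this pair.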